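Fluoropyridyl for fluorophenyl on a weaker reversed-chalcone core

This account rests on a few compounds, and the source may have more. Where it says the series, first, only, none or still open, it means among the compounds named here.

Measured so far:
compound 1, `COc1ccc(/C=C/C(=O)c2ccccc2-c2ccc(F)cc2)cc1`, 53 nM
compound 2, `COc1ccc(/C=C/C(=O)c2ccccc2-c2ccc(F)nc2)cc1`, 160 nM
compound 3, `COc1ccc(C(=O)/C=C/c2ccccc2-c2ccc(F)cc2)cc1OC`, 7600 nM

In a functional assay on CNE-2 cells (Homo sapiens) for antiproliferative activity, read by sulforhodamine B assay, with a stated time of 48 h (a lower number here means a stronger inhibitor, a higher number a weaker inhibitor), compound 1 gives 53 nM. Compound 2 differs from it by one change, (6-fluoropyridin-3-yl in place of 4-fluorophenyl on an aromatic carbon), and the step is a 3.0-fold higher number from compound 1 to compound 2 (0.48 log units; beyond the scatter). Compound 3, built on a different core, gives 7600 nM in this assay, the highest number of the three; how the two cores differ is not broken down here.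

Compound 4, `COc1ccc(C(=O)/C=C/c2ccccc2-c2ccc(F)nc2)cc1OC`, carries the same change on the core of compound 3: 6-fluoropyridin-3-yl in place of 4-fluorophenyl on an aromatic carbon. The place is described in the same words for both pairs, on an aromatic carbon of a six-membered aromatic ring of carbon only, ortho to a large group, so the change is the same one, seen twice in all. Within the data shown here, only one measured example of the step exists, and it sits on a different core, so the transfer is uncertain. The expected step from compound 3 to compound 4 is a 2.6-fold higher number from compound 3 to compound 4 (0.42 log units; beyond the scatter), resting on a 3.0-fold higher number from compound 1 to compound 2 (0.48 log units; beyond the scatter). Compound 4 is therefore estimated at 20000 nM, between 7000 nM and 60000 nM, in this assay.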

Compound 4, half-maximal inhibitory concentration: 17000 nM
Compound 4: the middle estimate sits 1.2-fold (0.07 log units) above what was measured, and the stated range covers the measured number.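

In this assay, placing 6-fluoropyridin-3-yl in place of 4-fluorophenyl on the core of compound 3 gives a 2.2-fold higher number from compound 3 to compound 4 (0.35 log units; beyond the scatter). Set beside the earlier pair, the change moves the number the same way on both cores, and the two steps cannot be told apart in size: the same change on two cores in this assay, a 3.0-fold higher number (0.48 log units; beyond the scatter) from compound 1 to compound 2 and a 2.2-fold higher number (0.35 log units; beyond the scatter) from compound 3 to compound 4, 1.3-fold (0.13 log units) apart, within the scatter of two such steps This agreement rests on only two pairs, so it shows that the step carried over between these two cores but does not show that it would hold on any further core in this series, nor does it explain why the number rises.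

The compounds shown leave open how other groups in this place would behave, such as an unsubstituted pyridine ring or a phenyl ring bearing an amine or a carboxylic acid. They also leave open which part of the difference between the two cores sets the much higher numbers of compound 3 and compound 4, since each measured pair changes only the fluorinated ring.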